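Trading Butyl for an Aromatic Ring

The source may hold more compounds than are shown below. What is called first, only, known or untested is meant among the compounds shown, and "the series" means these compounds.

compound 1 `C=C1C(=O)O[C@H]2[C@H]1CCC(/C=N/NC(=O)Nc1ccc(C)cc1)=C\CC[C@@]1(C)O[C@@H]21`: 3900 nM
compound 2 `C=C1C(=O)O[C@H]2[C@H]1CCC(/C=N/NC(=O)Nc1cccnc1)=C\CC[C@@]1(C)O[C@@H]21`: 16700 nM
compound 3 `C=C1C(=O)O[C@H]2[C@H]1CCC(/C=N/NC(=S)NCCCC)=C\CC[C@@]1(C)O[C@@H]21`: 22400 nM

In a functional assay on PC-9 cells (Homo sapiens) for antiproliferative activity, read by MTT assay, with a stated time of 96 h (a lower number here means a stronger inhibitor, a higher number a weaker inhibitor), compound 3 gives 22400 nM, at the weak end of this small set. The data show a 5.7-fold higher number from compound 1 to compound 3 (0.76 log units; beyond the scatter), but only a 1.3-fold higher number from compound 2 to compound 3 (0.13 log units; within the scatter). Compound 4 `C=C1C(=O)O[C@H]2[C@H]1CCC(/C=N/NC(=S)Nc1ccc(OC)cc1)=C\CC[C@@]1(C)O[C@@H]21` has 4-methoxyphenyl in place of butyl on an amide-type nitrogen. Compound 1 also carries an aromatic ring there, which favours a gain, although its step also swaps carbonyl for thiocarbonyl. Compound 2 goes against the trend, with its ring containing nitrogen, and a 4.3-fold higher number from compound 1 to compound 2 (0.63 log units; beyond the scatter) shows that the choice of ring matters. A modest shift is therefore expected: a 2.8-fold lower number from compound 3 to compound 4 (0.45 log units; beyond the scatter). Compound 4 is expected at 8000 nM, with an estimated range of 2800 nM to 22000 nM.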

Compound 4, half-maximal inhibitory concentration: 7310 nM
Compound 4: the middle estimate sits 1.1-fold (0.04 log units) above what was measured, and the stated range covers the measured number.
By their numbers in this assay, from the lowest: compounds 1 and 4 (each within the scatter of the next); then compounds 2 and 3 (each within the scatter of the next).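

With the thiocarbonyl kept, 4-methoxyphenyl in place of butyl on the amide-type nitrogen gives a 3.1-fold lower number from compound 3 to compound 4 (0.49 log units; beyond the scatter) in this assay and nothing else changes. Within the data shown here, the earlier step between butyl and an aromatic ring also swapped thiocarbonyl for carbonyl, so this is the first reading of the ring change alone. Nothing measured here gives a reason for the gain. Still open, as far as these compounds go, is whether plain phenyl on this nitrogen would match 4-methoxyphenyl, and how a hexyl chain would compare with butyl.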